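The source may hold more compounds than are shown below. What is called first, only, known or untested is meant among the compounds shown, and "the series" means these compounds.

Three compounds built on one shared core were tested in a functional assay on NCI-H460 cells (Homo sapiens) for cytotoxicity, read by MTT assay, with a stated time of 72 h; on this read-out higher numbers stand for weaker inhibition and lower numbers for stronger inhibition. Compound 1 `CN(C)CCn1cnnc1-c1cc(Oc2ccc(NC(=O)N/N=C/c3ccc(O)c(F)c3)cc2F)ccn1` gives 2620 nM in this assay. Compound 2 `COc1ccc(/C=N/NC(=O)Nc2ccc(Oc3ccnc(-c4nncn4CCN(C)C)c3)c(F)c2)cc1O` gives 620 nM, and compound 3 `CN(C)CCn1cnnc1-c1cc(Oc2ccc(NC(=O)N/N=C/c3c(Cl)cccc3Cl)cc2F)ccn1` gives 350 nM. The number for compound 3 is the lowest of the three; the step of a 1.8-fold lower number from compound 2 to compound 3 (0.25 log units; within the scatter) lies within the scatter, while the step of a 7.5-fold lower number from compound 1 to compound 3 (0.87 log units; beyond the scatter) lies beyond it.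

Compound 4 `CN(C)CCn1cnnc1-c1cc(Oc2ccc(NC(=O)N/N=C/c3ccc(O)cc3O)cc2F)ccn1` has not yet been measured. It differs from compound 3 in a single place: 2,4-dihydroxyphenyl in place of 2,6-dichlorophenyl on a carbon with a double bond to nitrogen. Going by the values given here, two measured steps bear on this change, each putting 2,6-dichlorophenyl in place of a group with a hydroxyl: a 7.5-fold lower number from compound 1 to compound 3 (0.87 log units; beyond the scatter) from 3-fluoro-4-hydroxyphenyl, and a 1.8-fold lower number from compound 2 to compound 3 (0.25 log units; within the scatter) from 3-hydroxy-4-methoxyphenyl. Compound 4 reverses that direction, so a modest rise in the number is expected rather than a fall. Compound 4 is estimated to give 1000 nM, with a likely range from 350 nM to 3000 nM. The expected step is a 2.9-fold higher number from compound 3 to compound 4 (0.46 log units; beyond the scatter).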

Compound 4, half-maximal inhibitory concentration: 11300 nM
The estimate for compound 4 lay 11-fold (1.05 log units) below the measured number, outside the stated range (above it).
By their numbers in this assay, from the lowest: compounds 3 and 2 (each within the scatter of the next); then compound 1; then compound 4.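

Having a hydroxyl at this position does not by itself set the number, since the three hydroxyl-bearing groups shown are far apart. Going by these compounds alone, replacing 2,6-dichlorophenyl with 2,4-dihydroxyphenyl on the carbon with a double bond to nitrogen gives a large loss of activity (a 32-fold higher number from compound 3 to compound 4 (1.51 log units; beyond the scatter)), much larger than the earlier steps suggested. Within the data shown here, the new group also falls behind both groups carrying a single hydroxyl (an 18-fold higher number from compound 2 to compound 4 (1.26 log units; beyond the scatter)) (a 4.3-fold higher number from compound 1 to compound 4 (0.63 log units; beyond the scatter)), so compound 4, the only compound here with two hydroxyls, has the highest number of the four.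

No measurement here explains why this group behaves so differently. Also open, as far as these compounds go, is how a plain phenyl, or a phenyl carrying an amine or a carboxylic acid, would compare at this position.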